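Racemate versus enantiomers on the pyrazole oxalamide series

The source may report more compounds than this note shows. Statements on the series, on what has been measured and on what is new or still open speak of the compounds shown alone.

Of the compounds shown here, three have numbers so far. Compound 1 `N#Cc1cnn(-c2ccccc2)c1NC(=O)C(=O)Nc1c(C#N)cnn1-c1ccccc1` gives 17.5 mg/kg in a functional assay on the whole organism (strain Wistar albino) for inhibition, with Rattus norvegicus as the target, read by paw edema, in the formalin test, with a stated time of 3 h; a lower number here means that less compound is needed, a higher number that more compound is needed for the effect. Compound 2 `CC(NC(=O)C(=O)Nc1c(C#N)cnn1-c1ccccc1)c1ccccc1` gives 19.6 mg/kg in this assay. Compound 3 `C[C@@H](NC(=O)C(=O)Nc1c(C#N)cnn1-c1ccccc1)c1ccccc1` gives 19 mg/kg in this assay, the second highest of the three numbers, and both neighbours sit within the scatter of it. Among the compounds with values here, the only single-place step measured is a 1.0-fold lower number from compound 2 to compound 3 (0.01 log units; within the scatter); what it rests on is the fact that one of compounds 2 and 3 is drawn with a defined configuration and the other without, at the place where they differ, so drawing one configuration in place of none left the number unchanged within the scatter.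

Compound 4 `C[C@H](NC(=O)C(=O)Nc1c(C#N)cnn1-c1ccccc1)c1ccccc1` is not yet measured. The change is the two compounds have the same atoms and bonds and differ only in configuration as drawn: 1 of 1 stereo elements differ; a stereocentre at a saturated chain carbon is drawn R in compound 3 and S in compound 4. Within the data shown here, the one measured step that bears on it, the one from compound 2 to compound 3, was within the scatter, and a racemate that reads the same as its defined enantiomer gives no reason to expect the mirror form to move. No step beyond the scatter is therefore expected in this assay. Compound 4 is estimated at 19.5 mg/kg, with a range of 13 mg/kg to 30 mg/kg. The step this estimate means, a 1.0-fold higher number from compound 3 to compound 4 (0.01 log units; within the scatter), is expected to stay within the scatter.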

Compound 4, dose for half-maximal effect: 22.4 mg/kg
Compound 4: middle estimate off by 1.1-fold (0.06 log units), on the low side; the measured number falls inside the stated range.
By their numbers in this assay, from the lowest: compounds 1, 3, 2 and 4 (each within the scatter of the next).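

In this assay the two drawn configurations at the saturated chain carbon can now be read directly against each other, giving a 1.2-fold higher number from compound 3 to compound 4 (0.07 log units; within the scatter), so R and S are not told apart at this position. The undefined drawing gives the same picture against S, with a 1.1-fold higher number from compound 2 to compound 4 (0.06 log units; within the scatter), so no two of the three forms at this carbon are separated. Unlike the earlier step, which set an undefined drawing against a defined one, this reading tests the configuration itself, and it rests on a single clean comparison: the fact that compounds 3 and 4 differ only in the configuration as drawn.

Open, from the compounds shown here alone, is whether a longer chain in place of the methyl at this stereocentre, or an amine on the phenyl, would let the two configurations separate. Also open, going by these compounds, is whether a carboxylic acid in place of the nitrile would leave the number where it stands.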